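The source may hold more compounds than are shown below. What is called first, only, known or untested is meant among the compounds shown, and "the series" means these compounds.

Working notes on the series

Of the compounds shown here, three of the shared core have been measured in an ADME assay on Left cardiac atrium (Cavia porcellus); a higher number here means that more compound is needed for the effect, a lower number that less compound is needed. Compound 1 `CCOC(=O)C1=C(C)NC(C)=C(C(=O)OCC)C1c1c(-c2ccccc2F)nc2sccn12` gives 5150 nM. Compound 2 `CCOC(=O)C1=C(C)NC(C)=C(C(=O)OCC)C1c1c(-c2ccc(F)cc2)nc2sc(Cl)cn12` gives 49 nM. Compound 3 `CCOC(=O)C1=C(C)NC(C)=C(C(=O)OCC)C1c1c(-c2ccc(Cl)cc2)nc2sccn12` gives 97 nM. Within these three, compound 3 stands second highest; the nearest is compound 2, within the scatter of compound 3, and the furthest is compound 1. For the measured compounds named here, the one single-point change recorded is a 53-fold lower number from compound 1 to compound 3 (1.73 log units; beyond the scatter).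

Compound 4 `CCOC(=O)C1=C(C)NC(C)=C(C(=O)OCC)C1c1c(-c2ccc(Cl)cc2)nc2sc(Cl)cn12` is the next member. From compound 3 the change is chloro in place of hydrogen on an aromatic carbon, the new chloro sitting on the five-membered aromatic ring with one nitrogen and one sulfur, next to the ring sulfur and two ring bonds from the ring nitrogen. Going by the values given here, no measured step isolates this change. Compound 2 carries the same chloro on the five-membered ring but with a 4-fluorophenyl rather than a 4-chlorophenyl, and its value and that of compound 3 lie within the scatter of each other; the recorded step from compound 1 to compound 3 concerns the phenyl substituent, not the five-membered ring, and so does not bear on it. The expectation is therefore a step of a 1.4-fold lower number from compound 3 to compound 4 (0.14 log units; within the scatter), that is, none beyond the scatter. Compound 4 is estimated at 70 nM in this assay, with a range of 20 nM to 250 nM.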

Compound 4, half-maximal effective concentration: 3500 nM
The estimate for compound 4 lay 50-fold (1.70 log units) below the measured number; the measured number lies above the stated range.
By their numbers in this assay, from the lowest: compounds 2 and 3 (each within the scatter of the next); then compounds 4 and 1 (each within the scatter of the next).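

In this assay, for the compounds shown here, the chloro on the aromatic carbon next to the ring sulfur is not a neutral addition, since placing it on the 4-chlorophenyl compound gives a 36-fold higher number from compound 3 to compound 4 (1.56 log units; beyond the scatter) and moves the series into the high range that had so far held only the 2-fluorophenyl compound. The same chloro does not give a high number in every setting: with that chloro held in place, exchanging fluoro for chloro on the phenyl ring gives a 71-fold higher number from compound 2 to compound 4 (1.85 log units; beyond the scatter), so the effect of each change depends on the group at the other place, and the two cannot be treated as independent within these compounds. Nothing available bears on why the two chloro groups together give this result.

From the compounds shown here alone, it remains open whether this dependence is specific to chloro on the five-membered ring or would also appear with a methyl group, a bromo group or an amine on the same aromatic carbon. Going by these compounds, it is equally open whether a bromo or methoxy group in place of the chloro on the phenyl ring would behave like fluoro or like chloro when the ring chloro is present.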